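The compounds below may be only part of what the source reports. "The series", "measured", "known", "first", "only" and "open" are said of these compounds alone.

Measured so far in a functional assay on A2780 cells (Homo sapiens) for antiproliferative activity; on this read-out higher numbers stand for lower toxicity in this test and lower numbers for higher toxicity in this test:

compound 1, `C[C@H]1CC(Cl)=C([Si](C)(C)C)[C@@H](C2CCCCC2)O1`, 61000 nM
compound 2, `C[C@@H]1O[C@H](C2CCCCC2)C([Si](C)(C)C)=C(Cl)[C@H]1C`, 77000 nM

Within the data shown here, compound 2 gives the higher of the two numbers in this assay; its only neighbour is compound 1, and the step of a 1.3-fold higher number from compound 1 to compound 2 (0.10 log units; within the scatter) lies within the scatter, so the two compounds are not separated on this read-out.

Compound 3, `C[C@@H]1O[C@H](CCC=C(Br)Br)C([Si](C)(C)C)=C(Cl)[C@H]1C`, is not yet measured. It differs from compound 2 by 4,4-dibromobut-3-en-1-yl in place of cyclohexyl on a saturated ring carbon. Among the measured compounds shown here, no measured step bears on this change: the one step available, a 1.3-fold higher number from compound 1 to compound 2 (0.10 log units; within the scatter), concerns a methyl on a saturated ring carbon and says nothing about the group that sits next to the ring oxygen. For the measured compounds named here, with no step to lean on, the expectation for compound 3 is a number close to that of compound 2, with no change beyond the scatter predicted, so the step of a 1.3-fold lower number from compound 2 to compound 3 (0.11 log units; within the scatter) is an estimate only. Compound 3 is therefore expected to give about 60000 nM in this assay, within a range of 15000 nM to 240000 nM.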

Compound 3, concentration lethal to 50% of the cells: 70000 nM
Compound 3: the middle estimate sits 1.2-fold (0.07 log units) below what was measured, within the range that was stated.
By their numbers in this assay, from the lowest: compounds 1, 3 and 2 (each within the scatter of the next).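

In this assay the change on the saturated ring carbon next to the ring oxygen, 4,4-dibromobut-3-en-1-yl in place of cyclohexyl, gives a 1.1-fold lower number from compound 2 to compound 3 (0.04 log units; within the scatter) and so does not separate the two compounds. Among these compounds, this is the only reading on this position, as the earlier step concerned a methyl on a different saturated ring carbon; here an open chain with one double bond and two bromine atoms replaces a ring of carbon only, and the read-out does not register the exchange. Nothing measured on hand accounts for this outcome.

As far as these compounds go, whether an amine or a carboxylic acid at the end of the chain, or a phenyl ring in place of cyclohexyl, would give a step beyond the scatter remains open. Also open, from the compounds shown here alone, is whether a change at the chloro group would do so.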